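Methoxy in place of hydroxy on a triazine thiazolidinone series

A few compounds are considered here, and "the series" means these few. Any claim that something is new, unique, unknown or untested is made for them only; others in the source may bear on it.

Compound 1 `CN1CCN(c2nc(Oc3ccc(C#N)cc3)nc(-c3ccc(N4C(=O)CSC4c4ccc(O)cc4)cc3)n2)CC1` carries a hydroxy group on the ring attached to the thiazolidinone. In an ADME assay on Vero cells (Chlorocebus sabaeus) for cytotoxicity, read by MTT assay, with a stated time of 72 h (a higher number here means a weaker inhibitor, a lower number a stronger inhibitor), compound 1 gives only a limit of the assay, > 62.5 ug/mL. Compound 2 `COc1ccc(C2SCC(=O)N2c2ccc(-c3nc(Oc4ccc(C#N)cc4)nc(N4CCN(C)CC4)n3)cc2)cc1` differs by methyl in place of hydrogen on an oxygen on an aromatic ring. In this assay compound 2 likewise gives only a limit, > 62.5 ug/mL. That step is a step that the two limits leave unreadable from compound 1 to compound 2. Compound 3 `CN1CCN(c2nc(Oc3ccc(C#N)cn3)nc(-c3ccc(N4C(=O)CSC4c4ccc(O)cc4)cc3)n2)CC1` differs from compound 1 by 5-cyanopyridin-2-yl in place of 4-cyanophenyl on an oxygen on an aromatic ring, and in this assay compound 3 gives only a limit, > 62.5 ug/mL; the step is a step that the two limits leave unreadable from compound 1 to compound 3. Compound 4 `COc1ccc(C2SCC(=O)N2c2ccc(-c3nc(Oc4ccc(C#N)cn4)nc(N4CCN(C)CC4)n3)cc2)cc1`, not yet measured, differs from compound 3 by methyl in place of hydrogen on an oxygen on an aromatic ring, the same change as from compound 1 to compound 2. The expected step is a step that the limit leaves unreadable from compound 3 to compound 4, resting on (the limit of > 62.5 ug/mL in this assay, at which 3 of the 3 values shown sit). Compound 4 is therefore estimated at 100 ug/mL, between 62.5 ug/mL and 250 ug/mL.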

Compound 4, half-maximal inhibitory concentration: > 62.5 ug/mL
Compound 4 was reported as a limit (the forecaster's own chance of this, stated with the estimate: 85%); the middle value lies beyond the limit too.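

Compound 4 gives only a limit, so its steps from compound 3 and from compound 2 cannot be read: the limit of > 62.5 ug/mL in this assay, at which 4 of the 4 values shown sit. The compounds shown leave open what size, if any, either change has in this assay.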